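The source may report more compounds than this note shows. Statements on the series, on what has been measured and on what is new or still open speak of the compounds shown alone.

Measured so far:
compound 1 `CCOC(=O)c1c(C)nc(-c2ccccc2)n1OC`, > 30000 nM
compound 2 `CCOC(=O)COn1c(-c2cccc(C#N)c2)nc(C)c1C(=O)OCC`, 6800 nM

Compound 1 gives in a functional assay on a cell-free system (plasma, Oryctolagus cuniculus) for inhibition, with stated times of 5 min, 1 min and 6 min (a lower number here means a stronger inhibitor, a higher number a weaker inhibitor), only a limit, > 30000 nM. Compound 2 gives a number in this assay, 6800 nM, the only number shown there. Compound 3 `CCOC(=O)c1c(C)nc(-c2cccc(C#N)c2)n1OCc1ccc(OC)cc1` is not yet measured. It differs from compound 2 by 4-methoxyphenyl in place of ethoxycarbonyl on a saturated chain carbon bound to an oxygen on an aromatic ring: ethoxycarbonyl leaves and 4-methoxyphenyl enters, the same change cut one bond further out reading (ethoxycarbonyl)methyl to 4-methoxybenzyl. Within the data shown here, no measured step covers a change of this kind, so the expectation rests on compound 2 alone; a modest gain is expected, a 2.3-fold lower number from compound 2 to compound 3 (0.36 log units; beyond the scatter), with a shift within the scatter in either direction quite possible. Compound 3 is expected at 3000 nM, within 600 nM to 15000 nM.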

Compound 3, half-maximal inhibitory concentration: 6830 nM
Beside the measured number, compound 3's estimate is 2.3-fold (0.36 log units) below it; measured number inside the range.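

In this assay the result reads a 1.0-fold higher number from compound 2 to compound 3 (0.00 log units; within the scatter). On this saturated chain carbon bound to an oxygen on an aromatic ring, ethoxycarbonyl and 4-methoxyphenyl therefore give no difference beyond the scatter, something compound 2 alone could not show. One value in the series is only a limit: the limit of > 30000 nM in this assay, at which 1 of the 3 values shown sits.

Still open, on these data alone, is whether an amine or a carboxylic acid on this carbon would move the number beyond the scatter. Also open, as far as these compounds go, is whether a longer chain carrying the same 4-methoxyphenyl would do so.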